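This account rests on a few compounds, and the source may have more. Where it says the series, first, only, none or still open, it means among the compounds named here.

In an ADME assay (liver) for metabolic stability, with Liver microsome (Rattus norvegicus) as the target, read by LC-MS, using microsomes and NADPH, with stated times of 5 min and 60 min, tested at 4 uM (on this read-out higher numbers stand for a more stable compound and lower numbers for a less stable compound), compound 1 `Cc1cc(C(=O)O)ccc1OCCCCOc1ccc(C(=O)CC(C)C)c(O)c1C` gives 41%, the highest of the three numbers available. Compound 2 `CCCC(=O)c1ccc(OCCCCOc2cc(C(=O)O)ccc2OC)c(C)c1O` gives 1% and compound 3 `COc1ccc(C(=O)O)cc1OCCCCOc1ccc(C(=O)CC2CCCC2)c(O)c1C` gives 14%, and both lie beyond the scatter from compound 1. The unmeasured compound 4 `Cc1cc(OCCCCOc2ccc(C(=O)CC(C)C)c(O)c2C)ccc1C(=O)O` has the same atoms as compound 1, joined differently: 4-carboxy-3-methylphenyl in place of 4-carboxy-2-methylphenyl on an oxygen on a saturated carbon. In words, 4-carboxy-3-methylphenyl stands in place of 4-carboxy-2-methylphenyl on an oxygen on a saturated carbon. For the measured compounds named here, only one measured step exists, a number 13 percentage points higher from compound 2 to compound 3 (beyond the scatter), and it is modest. Going by the values given here, that step concerns a saturated chain carbon bound to a carbonyl carbon, not the place that changes here, so it shows only that one change can move this number. Among the compounds with values here, no measured pair makes the swap from compound 1 to compound 4, so the data give no direction. The expected change, a number 6 percentage points lower from compound 1 to compound 4 (within the scatter), is therefore estimated to stay within the scatter. Compound 4 is estimated at 35%, with an expected range from 15% to 55%.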

Compound 4, percent of the compound remaining: 57%
Compound 4: the middle estimate sits 22 percentage points below what was measured; the whole stated range lies below it.
By their numbers in this assay, from the lowest: compound 2; then compound 3; then compound 1; then compound 4.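

In this assay, 4-carboxy-3-methylphenyl in place of 4-carboxy-2-methylphenyl gives a number 16 percentage points higher from compound 1 to compound 4 (beyond the scatter) at the place on an oxygen on a saturated carbon. For the compounds shown here, this is the first measured step at this place, and it shows that the number can respond to a rearrangement within this group even though no atoms are added or lost. Nothing available explains why the number rises with this change.

On these data alone, it remains open whether the same swap would give a similar step on the other compounds here, which carry different groups on the carbonyl side of the molecule. Also unknown is how the number would respond to a chlorine atom or a trifluoromethyl group in place of the methyl, or to an amide in place of the carboxylic acid.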